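This account rests on a few compounds, and the source may have more. Where it says the series, first, only, none or still open, it means among the compounds named here.

Compound 3 `CC(Oc1ccccc1OC1CC1)C1=NCCN1` gives 47.9 nM in a functional assay on CHO cells for agonist activity at Alpha-2C adrenergic receptor (Homo sapiens) (a lower number here means that less compound is needed, a higher number that more compound is needed for the effect), the second highest of the three numbers recorded there: compound 1 `CC(Oc1ccccc1Br)C1=NCCN1` gives 10 nM, and compound 2 `CCOc1ccccc1OC(C)C1=NCCN1` gives 10000 nM. Two measured steps lead into compound 3, namely a 4.8-fold higher number from compound 1 to compound 3 (0.68 log units; beyond the scatter) and a 210-fold lower number from compound 2 to compound 3 (2.32 log units; beyond the scatter); a third, a 1000-fold higher number from compound 1 to compound 2 (3.00 log units; beyond the scatter), shows how far the number can move when the group on this aromatic carbon is exchanged. Compound 4 `CC(Oc1ccccc1S(C)(=O)=O)C1=NCCN1` differs from compound 3 by methylsulfonyl in place of cyclopropyloxy on an aromatic carbon. Among the compounds with values here, none of the measured steps involves methylsulfonyl, so the direction can only be inferred from the spread between compound 1 and compound 2, which shows that this position accepts some groups well and others poorly. Given that spread, a large step upward is expected in this assay for compound 4, roughly a 21-fold higher number from compound 3 to compound 4 (1.32 log units; beyond the scatter). Compound 4 is therefore estimated at 1000 nM, with a range from 100 nM to 10000 nM.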

Compound 4, half-maximal effective concentration: 316 nM
Compound 4: middle estimate off by 3.2-fold (0.50 log units), on the high side; low and high end bracket the measured number.
By their numbers in this assay, from the lowest: compound 1; then compound 3; then compound 4; then compound 2.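

In this assay, methylsulfonyl falls between the earlier groups on this aromatic carbon, with a 32-fold higher number from compound 1 to compound 4 (1.50 log units; beyond the scatter) and a 32-fold lower number from compound 2 to compound 4 (1.50 log units; beyond the scatter), so this position accepts it far better than ethoxy but clearly less well than bromo. Cyclopropyloxy and methylsulfonyl have the same number of heavy atoms, yet the exchange still gives a 6.6-fold higher number from compound 3 to compound 4 (0.82 log units; beyond the scatter), which shows that heavy-atom count alone does not set the number here. No measurement is available that accounts for the order of these four groups.

On these data alone, it remains open where an amine, a carboxylic acid or a longer chain on this carbon would fall in that order, and whether any group would give a lower number than bromo. Whether the order holds when the shared core is changed elsewhere is also left open.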